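The source may hold more compounds than are shown below. What is called first, only, known or untested is meant among the compounds shown, and "the series" means these compounds.

Measured so far:
compound 1, `COC(=O)c1ccc(Cl)cc1OC(=O)COc1cc(O)c2c(=O)cc(-c3ccccc3)oc2c1`, 12400 nM
compound 2, `COC(=O)c1cc(Br)ccc1OC(=O)COc1cc(O)c2c(=O)cc(-c3ccccc3)oc2c1`, 780 nM

In a functional assay on cells (T-cell, Mus musculus, strain BALB/c) for inhibition, read by MTT assay, with a stated time of 72 h (on this read-out lower numbers stand for stronger inhibition and higher numbers for weaker inhibition), compound 1 gives 12400 nM. Compound 2 stands lowest of the two numbers shown; its nearest neighbour is compound 1, and the step is a 16-fold lower number from compound 1 to compound 2 (1.20 log units; beyond the scatter). That single step is the only one measured, and it carries two changes at once, a different halogen and a different position of that halogen, so it speaks to the present change only in part.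

Compound 3, `COC(=O)c1cc(F)ccc1OC(=O)COc1cc(O)c2c(=O)cc(-c3ccccc3)oc2c1`, has not yet been measured in this assay. It differs from compound 2 by fluoro in place of bromo on an aromatic carbon. Going by the values given here, no measured pair isolates a swap of one halogen for another at the same aromatic carbon, so the direction of the step is open. Since the large step of a 16-fold lower number from compound 1 to compound 2 (1.20 log units; beyond the scatter) shows that this part of the molecule matters, a change beyond the scatter is plausible, and a move back toward the higher number of compound 1 is expected more than a further fall. Compound 3 is therefore estimated at 1600 nM, within 500 nM to 5000 nM, an expected step of a 2.1-fold higher number from compound 2 to compound 3 (0.31 log units; beyond the scatter).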

Compound 3, half-maximal inhibitory concentration: 6820 nM
Beside the measured number, compound 3's estimate is 4.3-fold (0.63 log units) below it; the whole stated range lies below it.
By their numbers in this assay, from the lowest: compound 2; then compounds 3 and 1 (each within the scatter of the next).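

In this assay, the pair of compound 2 and compound 3 isolates the halogen at one aromatic carbon, meta to a methoxycarbonyl group and para to a large group, and the swap gives an 8.7-fold higher number from compound 2 to compound 3 (0.94 log units; beyond the scatter). With the place held fixed, the identity of the halogen alone therefore moves the number well beyond the scatter, something the earlier step could not show, since it changed halogen and place together. The further comparison gives a 1.8-fold lower number from compound 1 to compound 3 (0.26 log units; within the scatter), so the 4-fluoro and 5-chloro compounds cannot be told apart here, and having a halogen at this carbon does not by itself bring the number down to that of compound 2, which among these compounds is reached only with bromo.

No measurement at hand accounts for the gap between bromo and fluoro at this carbon. On these data alone, it remains open how chloro at this same carbon would compare with compound 1, which would separate place from halogen, and whether iodo, a methyl group or an amine there would stay near compound 2 or near compound 3.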